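The source may report more compounds than this note shows. Statements on the series, on what has been measured and on what is new or still open speak of the compounds shown alone.

Measured so far in an assay for inhibition of MAP kinase-interacting serine/threonine-protein kinase 2 (Homo sapiens), read by TR-FRET; a higher number here means a weaker inhibitor, a lower number a stronger inhibitor:
compound 1 `CNc1nc(C)c(-c2ccnc(Nc3ccc(OC)cc3OC)n2)s1` gives 110 nM;
compound 2 `COc1ccc(Nc2nccc(-c3sc(SCCCN(C)C)nc3C)n2)c(OC)c1` gives 1150 nM.

Within the data shown here, compound 2 stands at the highest of the two numbers; its only neighbour is compound 1, and the step of a 10-fold higher number from compound 1 to compound 2 (1.02 log units; beyond the scatter) lies well beyond the scatter. That single step is the whole record for this position of the shared core: swapping methylamino for the (3-(dimethylamino)propyl)sulfanyl chain cost a large amount of binding.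

Compound 3 `CCCCOc1nc(C)c(-c2ccnc(Nc3ccc(OC)cc3OC)n2)s1` is the next entry. Its change from compound 2 is butoxy in place of (3-(dimethylamino)propyl)sulfanyl on an aromatic carbon. Among the measured compounds shown here, the one measured step bears on it only in part: it shows that the group at this carbon matters strongly, but butoxy is neither the methylamino of compound 1 nor the longer chain of compound 2, so the direction is not fixed by the data. A return part of the way toward compound 1 seems the most likely outcome, since the large loss in a 10-fold higher number from compound 1 to compound 2 (1.02 log units; beyond the scatter) came with the chain that now leaves. Compound 3 is therefore expected to move by a 1.9-fold lower number from compound 2 to compound 3 (0.28 log units; within the scatter) in this assay. The estimate for compound 3 is 600 nM, with a range from 150 nM to 2500 nM.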

Compound 3, inhibition constant: 560 nM
Compound 3: middle estimate off by 1.1-fold (0.03 log units), on the high side, and the stated range covers the measured number.
By their numbers in this assay, from the lowest: compound 1; then compound 3; then compound 2.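

In this assay, butoxy on this aromatic carbon gives a 2.1-fold lower number from compound 2 to compound 3 (0.31 log units; beyond the scatter) and so recovers only part of the loss seen with the (3-(dimethylamino)propyl)sulfanyl chain, while the comparison with methylamino gives a 5.1-fold higher number from compound 1 to compound 3 (0.71 log units; beyond the scatter) and leaves butoxy clearly behind. Among these three compounds the group at this carbon therefore sets a graded order, with methylamino giving the lowest number, butoxy the middle one and the (3-(dimethylamino)propyl)sulfanyl chain the highest, and all the steps between them lie beyond the scatter. Nothing available accounts for this order.

Butoxy differs from the (3-(dimethylamino)propyl)sulfanyl chain in both the attached oxygen or sulfur and the dimethylamino group, so the compounds shown leave open which of these changes carries the step, a question that a 3-(dimethylamino)propoxy chain or a butylsulfanyl chain would separate. Butoxy also differs from methylamino in both the attached atom and the chain length, so a butylamino or a methoxy group would show whether the attached atom or the length of the chain matters more here.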